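Working notes: from compound 1 to compound 3

This account rests on a few compounds, and the source may have more. Where it says the series, first, only, none or still open, it means among the compounds named here.

Measured in a functional assay on HeLa cells (Homo sapiens) for antiproliferative activity, read by MTT assay, with a stated time of 48 h; a lower number here means a stronger inhibitor, a higher number a weaker inhibitor
- compound 1 `COc1cc(CNC(=O)CCCCCCC(C)C)ccc1OCCCCOc1ccc(C(N)=S)cc1` gives 40700 nM
- compound 2 `COc1cc(CNC(=O)CCCC/C=C/C(C)C)ccc1OC(=O)c1ccc(C(N)=S)cc1` gives 39600 nM

Within the data shown here, compound 1 stands level with compound 2, the only other measured compound in this set, as the two values lie within the usual scatter of each other. Compound 3 `COc1cc(CNC(=O)CCCC/C=C/C(C)C)ccc1OCCCCOc1ccc(C(N)=S)cc1` has not yet been measured. It differs from compound 1 by 3-methylbut-1-en-1-yl in place of isopentyl on a saturated chain carbon, four bonds along the chain from a carbonyl carbon. Among the measured compounds shown here, no measured pair isolates this change, so its size in this assay can only be expected. With compound 1 at 40700 nM as the starting point, no step beyond the scatter is expected in either direction. The estimated 1.1-fold lower number from compound 1 to compound 3 (0.03 log units; within the scatter) remains small. The expected value for compound 3 is 38000 nM within an estimated range of 19000 nM to 70000 nM in this assay.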

Compound 3, half-maximal inhibitory concentration: > 50000 nM
Compound 3 ended at the assay's limit; the forecaster's own chance of this, stated with the estimate: 10%; middle value at least 1.3-fold (0.11 log units) from the limit.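

In this assay compound 3 gives > 50000 nM, which is a limit of the assay and not a number. With 3-methylbut-1-en-1-yl in place of isopentyl on a saturated chain carbon, four bonds along the chain from a carbonyl carbon, the series now has its first read step at this position, an at least 1.2-fold higher number from compound 1 to compound 3 (0.08 log units; that floor lies within the scatter), and the change gives no lower number than the saturated chain of compound 1. Only a floor of this step can be read, and the true size stays unknown: the limit of > 50000 nM in this assay, at which 1 of the 3 values shown sits.

As far as these compounds go, whether the step goes beyond the scatter remains open, since the floor lies within it. Also open, from the compounds shown here alone, is how this position responds to other groups at the chain end, such as a terminal amine, a carboxylic acid or a longer saturated chain.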